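Methoxy in place of chloro: cytotoxicity of compound 4

The source may report more compounds than this note shows. Statements on the series, on what has been measured and on what is new or still open speak of the compounds shown alone.

Compound 1 `O=[N+]([O-])c1cn2c(n1)OC[C@@H](OCc1ccc(-c3ccc(OC(F)(F)F)cc3)cc1Cl)C2` gives > 128000 nM in an ADME assay on Vero cells (Chlorocebus sabaeus) for cytotoxicity, with a stated time of 72 h (a lower number here means a stronger inhibitor, a higher number a weaker inhibitor), a limit of the assay rather than a number.
Compound 2 `O=[N+]([O-])c1cn2c(n1)OC[C@@H](OCc1ccc(-c3ccc(OC(F)(F)F)cc3)c(Cl)c1)C2` gives > 128000 nM in this assay, likewise a limit.
Compound 3 `O=[N+]([O-])c1cn2c(n1)OC[C@@H](OCc1ccc(-c3ccc(C(F)(F)F)cn3)cc1F)C2` gives > 128000 nM in this assay, also a limit.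

Within the data shown here, compound 1 therefore stands at the limit of > 128000 nM in this assay, at which 3 of the 3 values shown sit, and no measured pair differs in only one place, so no measured step is available. Compound 4 `COc1cc(-c2ccc(OC(F)(F)F)cc2)ccc1CO[C@@H]1COc2nc([N+](=O)[O-])cn2C1` differs from compound 1 by methoxy in place of chloro on an aromatic carbon. With every measured compound at the limit, no movement beyond the usual scatter is expected in this assay. Compound 4 is expected to give 128000 nM, within 64000 nM to 256000 nM. The expected change a number no higher from compound 1 to compound 4 (the limit leaves the size open) is none beyond the scatter.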

Compound 4, half-maximal inhibitory concentration: > 128000 nM
Compound 4: no number, only a limit; the forecaster's own chance of this, stated with the estimate: 85%; the middle value sits exactly at the limit.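

Compound 1 and compound 4 both sit at a limit of this assay, so no step can be read between them: the limit of > 128000 nM in this assay, at which 4 of the 4 values shown sit.

The compounds shown leave open whether methoxy and chloro differ at all in this assay.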